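Sec-Butyl to Isopropyl: One Carbon Removed

The compounds below may be only part of what the source reports. "The series", "measured", "known", "first", "only" and "open" are said of these compounds alone.

compound 1 `Nc1ccccc1NC(=O)/C=C/c1ccc(Cn2cnc3c(NC4CCCCC4)nc(Cl)nc32)cc1`: 24.9%
compound 2 `CCC(C)n1cnc2c(NCc3ccc(C(=O)Nc4ccccc4N)cc3)nc(Cl)nc21`: 67.7%

In a functional assay on NCI-H460 cells (Homo sapiens) for antiproliferative activity, read by CCK-8 assay, with a stated time of 72 h, tested at 8 uM (a lower number here means a weaker effect, a higher number a stronger effect of the compound at the concentration tested), compound 1 gives 24.9%, and compound 2 gives 67.7%. Within the data shown here, compound 2 stands highest of the two numbers, beyond the scatter above compound 1; no single-change step links them, so only their two values are known. Compound 3 `CC(C)n1cnc2c(NCc3ccc(C(=O)Nc4ccccc4N)cc3)nc(Cl)nc21` differs from compound 2 by hydrogen in place of methyl on a saturated chain carbon, two bonds along the chain from an aromatic nitrogen. No measured step of this kind exists among these compounds, so the change is expected to give a step within the scatter, leaning if anything toward a small decrease. Compound 3 is estimated at 60%, between 40% and 78%. The expected step is a number 7.7 percentage points lower from compound 2 to compound 3 (within the scatter).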

Compound 3, a percentage reported as inhibition, at one concentration (the size of the read-out at that concentration, not a potency): 80.5%
Compound 3: middle estimate off by 20.5 percentage points, on the low side, outside the stated range (above it).
By their numbers in this assay, from the lowest: compound 1; then compound 2; then compound 3.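

This is the first single-change step among these compounds. In this assay, replacing sec-butyl with isopropyl gives a number 12.8 percentage points higher from compound 2 to compound 3 (beyond the scatter), so the read-out at this position responds to the removal of one methyl from the saturated chain carbon. Nothing measured here explains why the read-out moves with this change.

Going by these compounds, whether the read-out would keep rising with a still smaller group, such as an ethyl or a methyl, remains open. So does the effect of a cyclopentyl ring or a hydroxyethyl chain at this place.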